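The compounds below may be only part of what the source reports. "The series", "measured", "known", "first", "only" and "open" are said of these compounds alone.

The compounds below share one core and are compared in an ADME assay on GES1 cells (Homo sapiens) for inhibition, read by MTT assay, with a stated time of 72 h; on this read-out lower numbers stand for stronger inhibition and higher numbers for weaker inhibition. Compound 1, with structure `Cc1cc(Nc2cc(-c3ccccc3)[nH]n2)n2nc(SCc3c(Cl)cccc3Cl)nc2n1`, gives 39600 nM in this assay. Compound 3, with structure `Cc1cc(Nc2ccn(Cc3ccc(C(F)(F)F)cc3)n2)n2nc(SCc3ccc(Br)cc3)nc2n1`, gives 30200 nM. Compound 2, with structure `Cc1ccc(Cn2ccc(Nc3cc(C)nc4nc(SCc5ccc(Br)cc5)nn34)n2)cc1`, gives > 50000 nM, and this is a limit of the assay rather than a number: the limit of > 50000 nM in this assay, at which 1 of the 3 values shown sits. Of the two numbers shown, compound 1's is the higher one, but its gap to compound 3 lies within the scatter. Going by the values given here, the only measured step, an at least 1.6-fold lower number from compound 2 to compound 3 (0.21 log units; that floor lies within the scatter), concerns trifluoromethyl in place of methyl on an aromatic carbon, and its floor also lies within the scatter.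

Compound 4, with structure `Cc1cc(Nc2cc(-c3ccccc3)[nH]n2)n2nc(SCC3CC3)nc2n1`, differs from compound 1 in one place: cyclopropyl in place of 2,6-dichlorophenyl on a saturated chain carbon bound to a sulfur. Among the compounds with values here, none of the measured steps touches the group on the saturated chain carbon bound to the sulfur; nothing among them points toward a shift in either direction. Compound 4 is therefore expected to stay close to compound 1, with an expected step of a 1.0-fold higher number from compound 1 to compound 4 (0.00 log units; within the scatter). The estimate for compound 4 in this assay is 40000 nM, with a range from 15000 nM to 100000 nM.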

Compound 4, half-maximal inhibitory concentration: > 50000 nM
Compound 4: a limit, no number; the forecaster's own chance of this, stated with the estimate: 35%; middle value at least 1.2-fold (0.09 log units) from the limit.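

In this assay, this is the first step among these compounds that touches the group on the saturated chain carbon bound to a sulfur, and it is an at least 1.2-fold higher number from compound 1 to compound 4 (0.10 log units; that floor lies within the scatter). Compound 4 gives > 50000 nM, which is a limit of the assay and not a number, so the step has a floor but no known size: the true gap could be small or much larger. Cyclopropyl, with 3 heavy atoms against 8 for 2,6-dichlorophenyl, therefore shows no sign of a lower number at this position, and the weak end of the scale gives these compounds little room for finer comparison: the limit of > 50000 nM in this assay, at which 2 of the 4 values shown sit.

The compounds shown leave open whether an amine, a carboxylic acid or a longer chain on the same saturated chain carbon would give a measurable number, and which of those groups would give a lower or a higher one. They also leave open whether cyclopropyl in place of 2,6-dichlorophenyl would give the same result on a compound whose other groups differ from those of compound 1.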